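Branching the chain on the ring nitrogen of compound 2

A few compounds are considered here, and "the series" means these few. Any claim that something is new, unique, unknown or untested is made for them only; others in the source may bear on it.

Compound 1 `CCn1ccnc1/C=C/C(=O)/C=C/c1coc2ccccc2c1=O`: 1000 nM
Compound 2 `CCCCn1ccnc1/C=C/C(=O)/C=C/c1coc2ccccc2c1=O`: 2000 nM

Of the compounds shown here, two have been measured in a functional assay on LNCaP cells (Homo sapiens) for inhibition, read by WST assay, with a stated time of 3 days; on this read-out higher numbers stand for weaker inhibition and lower numbers for stronger inhibition. Compound 1 `CCn1ccnc1/C=C/C(=O)/C=C/c1coc2ccccc2c1=O` gives 1000 nM and compound 2 `CCCCn1ccnc1/C=C/C(=O)/C=C/c1coc2ccccc2c1=O` gives 2000 nM; compound 2 has the higher of the two numbers, but the step of a 2.0-fold higher number from compound 1 to compound 2 (0.30 log units; within the scatter) is within the scatter, so the two cannot be told apart. Compound 3 `CCC(C)n1ccnc1/C=C/C(=O)/C=C/c1coc2ccccc2c1=O` is not yet measured. It differs from compound 2 in one place: sec-butyl in place of butyl on an aromatic nitrogen. Going by the values given here, the only step known, from ethyl to butyl, stayed within the scatter, so no step beyond the scatter is expected for no change at the digits printed from compound 2 to compound 3 (within the scatter). Compound 3 is therefore estimated at 2000 nM, with a range from 800 nM to 5000 nM.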

Compound 3, half-maximal inhibitory concentration: 1300 nM
Compound 3: middle estimate off by 1.5-fold (0.19 log units), on the high side; the range from low to high includes it.
By their numbers in this assay, from the lowest: compounds 1, 3 and 2 (each within the scatter of the next).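

Sec-butyl in place of butyl on the aromatic nitrogen gives a 1.5-fold lower number from compound 2 to compound 3 (0.19 log units; within the scatter), so here the branched chain cannot be told apart from the straight one. Ethyl in place of hydrogen on the chain carbon bound to that nitrogen gives a 1.3-fold higher number from compound 1 to compound 3 (0.11 log units; within the scatter), so compound 3 also cannot be told apart from compound 1. No measurement at hand accounts for these small steps. Going by these compounds, whether a longer chain, or an amine or a carboxylic acid at the end of the chain, would move the number beyond the scatter remains open.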